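Methoxycarbonyl to carboxy: compound 3 to compound 4

The source may report more compounds than this note shows. Statements on the series, on what has been measured and on what is new or still open speak of the compounds shown alone.

In a functional assay on MCF7 cells (Homo sapiens) for inhibition (a lower number here means a stronger inhibitor, a higher number a weaker inhibitor), compound 1 (`CCCCCC[C@@]1(C)SC(=O)C=C1OC`) gives 14 ug/mL and compound 3 (`CCCCCC[C@@]1(C)SC(=O)C=C1OCC(=O)NCC(=O)OC`) gives 9.8 ug/mL, two values within the scatter of each other. Compound 3 therefore stands level with compound 1 at the active end of the series. Compound 2 (`C=CCOC1=CC(=O)S[C@]1(C)CCCCCC`) reaches only a limit of the assay, > 50 ug/mL.

Compound 4 (`CCCCCC[C@@]1(C)SC(=O)C=C1OCC(=O)NCC(=O)O`) is compound 3 with one change: hydrogen in place of methyl on an oxygen next to a carbonyl group. In words, hydrogen replaces methyl on an oxygen next to a carbonyl group, turning methoxycarbonyl into carboxy.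

Going by the values given here, the only measured step is an at least 3.5-fold higher number from compound 1 to compound 2 (0.55 log units; beyond the scatter). It is a different change, vinyl in place of hydrogen, so it bears only loosely, though it shows that this assay can respond to a change in this series. Among the compounds with values here, no measured step covers the present change.

The expected step is a 1.6-fold higher number from compound 3 to compound 4 (0.21 log units; within the scatter), leaning towards a weaker inhibitor and not firmly beyond the scatter. For compound 4 the estimated value is 16 ug/mL, with an expected range of 6 ug/mL to 45 ug/mL.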

Compound 4, half-maximal inhibitory concentration: 6.6 ug/mL
Beside the measured number, compound 4's estimate is 2.4-fold (0.38 log units) above it; the measured number falls inside the stated range.
By their numbers in this assay, from the lowest: compounds 4, 3 and 1 (each within the scatter of the next, the first and the last beyond it). At a limit, above all of these: compound 2.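

In this assay the carboxy end of the side chain is tolerated: the step is a 1.5-fold lower number from compound 3 to compound 4 (0.17 log units; within the scatter) and so hydrogen in place of methyl on an oxygen next to a carbonyl group leaves the reading level with the ester. The (carboxymethyl)carbamoyl group now gives a reading beyond the scatter, a 2.1-fold lower number from compound 1 to compound 4 (0.33 log units; beyond the scatter) being a separation the ester did not reach. A further reading, an at least 7.5-fold lower number from compound 2 to compound 4 (0.87 log units; beyond the scatter) is also beyond the scatter, but it starts from a limit and gives a bound only: the limit of > 50 ug/mL in this assay, at which 1 of the 4 values shown sits.

From the compounds shown here alone, whether an amine or a primary amide at the end of the side chain would read level with the carboxy group stays open, as does a longer chain ahead of that group. Going by these compounds, the effect of a shorter chain on the core also stays open.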